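Propylphenyl for methylphenyl on the aryl amine nitrogen

A few compounds are considered here, and "the series" means these few. Any claim that something is new, unique, unknown or untested is made for them only; others in the source may bear on it.

In an assay on FRT-Jurkat cells for inhibition of nuclear factor NF-kappa-B complex (Homo sapiens), read by flow cytometry, with a stated time of 24 h, tested at 10 uM (on this read-out lower numbers stand for less inhibition and higher numbers for more inhibition at the one concentration tested (going by the name of the read-out)), compound 1 `Cc1ccccc1Nc1cccc2c1C(=O)N(C1CCC(=O)NC1=O)C2=O` gives 7%. Compound 3 `CCOC(=O)c1ccc(Nc2ccc3c(c2)C(=O)N(C2CCC(=O)NC2=O)C3=O)cc1` gives 5% and compound 2 `CC(=O)c1ccc(Nc2ccc3c(c2)C(=O)N(C2CCC(=O)NC2=O)C3=O)cc1` gives -2%, so all three numbers lie within the scatter of one another and compound 1 is not set apart. Among the compounds with values here, the one step between measured neighbours, a number 7 percentage points higher from compound 2 to compound 3 (within the scatter), concerns ethoxy in place of methyl on a carbonyl carbon and stays within the scatter. Compound 4 `CCCc1ccc(Nc2cccc3c2C(=O)N(C2CCC(=O)NC2=O)C3=O)cc1` differs from compound 1 by 4-propylphenyl in place of 2-methylphenyl on a nitrogen on an aromatic ring. Within the data shown here, no measured pair shows this change; the only step available, from compound 2 to compound 3, concerns another place and was small. No step beyond the scatter is therefore expected, and compound 4 is estimated at 5% (range -10% to 20%), a change of a number 2 percentage points lower from compound 1 to compound 4 (within the scatter) expected.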

Compound 4, a percentage reported as inhibition, at one concentration (the size of the read-out at that concentration, not a potency): 23%
Compound 4: middle estimate off by 18 percentage points, on the low side; the whole stated range lies below it.
By their numbers in this assay, from the lowest: compounds 2, 3 and 1 (each within the scatter of the next); then compound 4.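

On a nitrogen on an aromatic ring, 4-propylphenyl in place of 2-methylphenyl gives a number 16 percentage points higher from compound 1 to compound 4 (beyond the scatter) and is the only step shown that lies beyond the scatter. The group at this place can therefore shift the read-out at the one concentration tested, which the earlier step at a carbonyl carbon did not show. No measured evidence accounts for this step.

The change alters both the chain and its place on the phenyl ring, so the compounds shown do not separate the two. Open too, going by these compounds, is how a longer chain, such as butyl, or an amine on that ring would read.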